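Acetyl on a chain carbon of compound 2

The source may hold more compounds than are shown below. What is called first, only, known or untested is meant among the compounds shown, and "the series" means these compounds.

Values measured in a functional assay on HCT-116 cells (Homo sapiens) for cytotoxicity, read by scintillation counting and thymidine incorporation, with a stated time of 72 h (a higher number here means a weaker inhibitor, a lower number a stronger inhibitor), are these
Compound 1 `C#CC=C(c1cc(OC)cc(OC)c1)c1ccc(OC)c(OC)c1` gives > 10000 nM (a limit)
Compound 2 `C=C(c1cc(OC)cc(OC)c1)c1ccc(OC)c(OC)c1` gives > 10000 nM (a limit)
Compound 3 `C=C(c1cc(OC)cc(OC)c1)c1ccc(OC)c(O)c1` gives 21 nM as a measured number

Compound 2 stands at > 10000 nM in this assay as a limit and not a number. Across this small set the picture is the limit of > 10000 nM in this assay, at which 2 of the 3 values shown sit, for now.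

Compound 4 `COc1cc(OC)cc(C(=CC(C)=O)c2ccc(OC)c(OC)c2)c1` carries acetyl in place of hydrogen on a double-bonded chain carbon bound to a double-bonded chain carbon, and acetyl in place of hydrogen on a double-bonded chain carbon bound to a double-bonded chain carbon is the whole of its difference from compound 2.

Among the compounds with values here, two measured steps bear on this change. The one at the same chain carbon is a step that the two limits leave unreadable from compound 1 to compound 2 and offers no size to carry over. The other is an at least 470-fold lower number from compound 2 to compound 3 (2.67 log units; beyond the scatter) and is large, but it sits on an oxygen on an aromatic ring, not on the chain. Since compound 4 keeps the methyl lost in an at least 470-fold lower number from compound 2 to compound 3 (2.67 log units; beyond the scatter) no step beyond the scatter is expected in this assay in either direction. The estimated step is a step that the limit leaves unreadable from compound 2 to compound 4 and a report of only a limit is likely. The expected value for compound 4 is 15000 nM with an estimated range from 5000 nM to 50000 nM in this read-out.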

Compound 4, half-maximal inhibitory concentration: > 10000 nM
Compound 4 gave a limit, no number; the forecaster's own chance of this, stated with the estimate: 85%; the middle value is on the limit's open side.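

In this assay compound 4 gives > 10000 nM, which is a limit and not a number. Within the data shown here, compound 1 and compound 2 also sit at limits, so no step from either to compound 4 can be read. The compounds shown leave open what acetyl on this chain carbon does when an aromatic-ring oxygen carries hydrogen in place of methyl, as in compound 3.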